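A few compounds are considered here, and "the series" means these few. Any claim that something is new, unique, unknown or untested is made for them only; others in the source may bear on it.

Notes on the series in a functional assay on HT-29 cells (Homo sapiens) for antiproliferative activity, read by MTT assay, with a stated time of 72 h, tested at 10 uM; on this read-out lower numbers stand for less inhibition and higher numbers for more inhibition at the one concentration tested (going by the name of the read-out).

For the measured compounds named here, compound 1 `CC(C)C(=O)Nc1cc(Oc2ccc(Nc3nccc4[nH]cc(-c5ccc(F)cc5)c(=O)c34)cc2F)ccn1` gives 83.4% in this assay, and it stands highest of the three numbers so far. Going by the values given here, compound 2 `Nc1nccc(Oc2ccc(Nc3nccc4[nH]cc(-c5ccc(F)cc5)c(=O)c34)cc2F)c1Cl` gives 56.2% in this assay, and the step of a number 27.2 percentage points lower from compound 1 to compound 2 (beyond the scatter) is the one measured single-point change in the set. Among the compounds with values here, compound 3 `CCn1cc(-c2ccc(F)cc2)c(=O)c2c(Nc3ccc(Oc4ccnc(NC(=O)C5CC5)c4)c(F)c3)nccc21` gives 15.8% in this assay, differing from compound 1 in more than one place, so no single step is drawn for that pair and the two values are simply what they show.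

Compound 4 `O=C(Nc1cc(Oc2ccc(Nc3nccc4[nH]cc(-c5ccc(F)cc5)c(=O)c34)cc2F)ccn1)C1CCC1` is not yet measured. Compared with compound 1 the change is cyclobutyl in place of isopropyl on a carbonyl carbon. Within the data shown here, no measured step touches the acyl group on the amide nitrogen: the step from compound 1 to compound 2 replaces the whole amide-bearing pyridinyl and is not a close guide to an isopropyl-to-cyclobutyl change. Among the measured compounds shown here, with no step of the relevant kind on record, the working expectation is that compound 4 stays close to compound 1, with a step of a number 3.4 percentage points lower from compound 1 to compound 4 (within the scatter) that is expected to lie within the usual scatter. The expected value for compound 4 in this assay is therefore 80%, with a range from 62% to 92%.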

Compound 4, a percentage reported as inhibition, at one concentration (the size of the read-out at that concentration, not a potency): 46%
Estimate against measurement, compound 4: 34 percentage points above; measured number below the stated range.
By their numbers in this assay, from the lowest: compound 3; then compound 4; then compound 2; then compound 1.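

In this assay the acyl group on the amide nitrogen turns out to be a sensitive place: cyclobutyl in place of isopropyl on a carbonyl carbon gives a number 37.4 percentage points lower from compound 1 to compound 4 (beyond the scatter), a large step, although only 3 heavy atoms leave, 4 enter, and the hydrogen-bond donor and acceptor counts and the net charge stay the same. The earlier measured step replaced the whole amide-bearing pyridinyl, whereas this one is confined to the carbon group on the carbonyl and shows that a small change there alone can move the inhibition at this one concentration by well beyond the scatter. No measurement on hand bears on why this change has so large an effect.

Open, going by these compounds, is whether the fall goes with the ring itself or with the larger carbon group, that is, whether a cyclopentyl, a tert-butyl or a straight propyl chain on the same carbonyl carbon would stand nearer compound 1 or nearer compound 4. Also open, on these data alone, is how a ring carrying an amine at this place would read, and whether the step would hold up as a potency across several concentrations.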